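The compounds below may be only part of what the source reports. "The series", "measured", "known", "first", "only" and "open" are said of these compounds alone.

In an assay on CHO cells for displacement of a labelled ligand from adenosine receptor A1 (Homo sapiens), read by scintillation counting, with a stated time of 60 min, tested at 10 uM (a higher number here means more inhibition at the concentration tested (going by the name of the read-out), a lower number less inhibition), three compounds sharing one core have been measured. Compound 1 `CNC(=O)[C@@]12C[C@@H]1[C@@H](n1cnc3c(NC)nc(C#Cc4cccc(F)c4)nc31)[C@H](O)[C@@H]2O` gives 14%, compound 2 `CNC(=O)[C@@]12C[C@@H]1[C@@H](n1cnc3c(NC)nc(C#Cc4ccccc4OC)nc31)[C@H](O)[C@@H]2O` gives 12%, and compound 3 `CNC(=O)[C@@]12C[C@@H]1[C@@H](n1cnc3c(NC)nc(C#Cc4ccc(OC)cc4)nc31)[C@H](O)[C@@H]2O` gives 10%. Compound 3 has the lowest of these three numbers, yet its gaps to the others are small: a number 4 percentage points lower from compound 1 to compound 3 (within the scatter) and a number 2 percentage points lower from compound 2 to compound 3 (within the scatter), both within the scatter, so the three stand as one group rather than in an order.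

Compound 4 `CNC(=O)[C@@]12C[C@@H]1[C@@H](n1cnc3c(NC)nc(C#Cc4ncccn4)nc31)[C@H](O)[C@@H]2O` differs from compound 3 in one place: pyrimidin-2-yl in place of 4-methoxyphenyl on a triple-bonded carbon. For the measured compounds named here, no measured step swaps the aromatic ring itself for a ring with hetero atoms; the steps that come closest, a number 2 percentage points lower from compound 1 to compound 2 (within the scatter), a number 4 percentage points lower from compound 1 to compound 3 (within the scatter) and a number 2 percentage points lower from compound 2 to compound 3 (within the scatter), only move or exchange a substituent on the phenyl ring, and each stays within the scatter. Those steps therefore give no reason to expect a change beyond the scatter for this assay, although the new ring is a larger change than any of them. Compound 4 is estimated at 10% in this assay, with a range from 0% to 25%, meaning an expected step of no change at the digits printed from compound 3 to compound 4 (within the scatter).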

Compound 4, a percentage reported as inhibition, at one concentration (the size of the read-out at that concentration, not a potency): 25%
Beside the measured number, compound 4's estimate is 15 percentage points below it; the range from low to high includes it.
By their numbers in this assay, from the lowest: compounds 3, 2 and 1 (each within the scatter of the next); then compound 4.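

In this assay this position proves able to move the number once the aromatic ring itself is exchanged, which no change of substituent on the phenyl ring had done: pyrimidin-2-yl gives a number 15 percentage points higher from compound 3 to compound 4 (beyond the scatter) and a number 13 percentage points higher from compound 2 to compound 4 (beyond the scatter) and a number 11 percentage points higher from compound 1 to compound 4 (beyond the scatter). Compound 4 therefore stands apart from the other three, which remain one group, although each step is modest. Nothing at hand explains the rise.

The ring exchange also removes the substituent and brings in ring nitrogens, and the compounds shown cannot separate these two differences. Also open, from the compounds shown here alone, is how this assay would read with an amine or a carboxylic acid on the pyrimidin-2-yl ring, or with a longer chain in place of the ring.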